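The compounds below may be only part of what the source reports. "The series", "measured", "known", "first", "only" and "open" are said of these compounds alone.

Three compounds have so far been measured in a functional assay on MGC-803 cells (Homo sapiens) for inhibition, read by MTT assay, with a stated time of 72 h; on this read-out higher numbers stand for weaker inhibition and lower numbers for stronger inhibition:

Compound 1 `CC(C)c1ccc(-c2nc(SCc3cn(CC(=O)NC(=O)Nc4ccccn4)nn3)nc(Nc3ccc(Cl)cc3)c2C#N)cc1`: > 64000 nM
Compound 2 `CC(C)c1ccc(-c2nc(SCc3cn(CC(=O)NC(=O)Nc4ccccn4)nn3)nc(Nc3cccc(C(F)(F)F)c3)c2C#N)cc1`: > 64000 nM
Compound 3 `COc1cc(-c2nc(SCc3cn(CC(=O)NC(=O)Nc4ccccn4)nn3)nc(Nc3cccc(C(F)(F)F)c3)c2C#N)cc(OC)c1OC`: 8210 nM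

Only compound 3 gives an actual number, 8210 nM. For compound 1 the value > 64000 nM is a limit of this assay, not a number. For compound 2 the value > 64000 nM is likewise a limit.

Compound 2 and compound 3 differ in the group attached to the core: 3,4,5-trimethoxyphenyl in place of 4-isopropylphenyl on an aromatic carbon. This exchange produces an at least 7.7-fold lower number from compound 2 to compound 3 (0.89 log units; beyond the scatter). Compound 2 and compound 1 differ instead in the group on the ring nitrogen: 4-chlorophenyl in place of 3-(trifluoromethyl)phenyl on a nitrogen on an aromatic ring. Here a step that the two limits leave unreadable from compound 2 to compound 1, since both compounds sit at the limit of > 64000 nM in this assay, at which 2 of the 3 values shown sit.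

Compound 4 `COc1cc(-c2nc(SCc3cn(CC(=O)NC(=O)Nc4ccccn4)nn3)nc(Nc3ccc(Cl)cc3)c2C#N)cc(OC)c1OC` is not yet measured. It stands to compound 3 as compound 1 stands to compound 2: 4-chlorophenyl in place of 3-(trifluoromethyl)phenyl on a nitrogen on an aromatic ring. The surroundings of the changed position are described in the same words in both pairs, so this is the same change, made on the core of compound 3 rather than that of compound 2.

The earlier instance of this change gives no readable size, so the expectation for compound 4 rests mainly on compound 3 and its value 8210 nM. Compound 4 is expected to show a step of about a 1.5-fold higher number from compound 3 to compound 4 (0.16 log units; within the scatter), staying near the starting point. Compound 4 is therefore estimated at roughly 12000 nM, most likely between 3000 nM and 50000 nM, with a fair chance that only a limit is reported.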

Compound 4, half-maximal inhibitory concentration: 17500 nM
Estimate against measurement, compound 4: 1.5-fold (0.16 log units) below; the measured number falls inside the stated range.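

In this assay, putting 4-chlorophenyl in place of 3-(trifluoromethyl)phenyl on the core of compound 3 gives a 2.1-fold higher number from compound 3 to compound 4 (0.33 log units; beyond the scatter), a modest step towards weaker inhibition; on the core of compound 2 the same change cannot be read, so this single readable instance cannot show whether the change carries over from one core to another. The other exchange, 3,4,5-trimethoxyphenyl in place of 4-isopropylphenyl, now appears twice, and with the new pair, an at least 3.6-fold lower number from compound 1 to compound 4 (0.56 log units; beyond the scatter), the number falls on both cores: the same change on two cores in this assay, an at least 7.7-fold lower number (0.89 log units; beyond the scatter) from compound 2 to compound 3 and an at least 3.6-fold lower number (0.56 log units; beyond the scatter) from compound 1 to compound 4; the limit leaves it open whether they differ. This shows a shared direction for these two pairs only, not a shared size, and the steps between compounds held at a limit cannot be read: the limit of > 64000 nM in this assay, at which 2 of the 4 values shown sit.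

The compounds shown leave open how a 3-chlorophenyl or a plain phenyl on the nitrogen would compare with the two groups seen there, which would help separate the effect of the atom from that of where it sits on the ring. They also leave open whether a single methoxy group on the phenyl ring would go with the stronger or the weaker values.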